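The source may report more compounds than this note shows. Statements on the series, on what has been measured and on what is new or still open speak of the compounds shown alone.

Measured so far:
compound 1 `CCc1cc(-c2cc(N3C[C@H](O)[C@@H](O)C3)ccc2O)nc(N)n1` — 1500 nM
compound 2 `Nc1nc(-c2cc(N3C[C@H](O)[C@@H](O)C3)ccc2O)cc(C2CCCNC2)n1` — > 10000 nM

Compound 1 carries an ethyl group on the shared core and in a functional assay on EJ cells (Homo sapiens) for cytotoxicity, with a stated time of 48 h (a higher number here means a weaker inhibitor of growth, a lower number a stronger inhibitor of growth), gives 1500 nM, the only plain number shown in this assay. Compound 2 carries piperidin-3-yl at the same position; its result is a limit of this assay, > 10000 nM, and not a number, so the step from compound 1 is itself only a bound: an at least 6.6-fold higher number from compound 1 to compound 2 (0.82 log units; beyond the scatter).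

Compound 3 `Nc1nc(-c2cc(N3C[C@H](O)[C@@H](O)C3)ccc2O)cc(C2CCCCCC2)n1` differs from compound 1 thus: cycloheptyl in place of ethyl on an aromatic carbon. Among the measured compounds shown here, the only measured step that bears on this change is the one to compound 2, where a larger ring in place of ethyl gave the weakening noted above; compound 3 also puts a ring in place of ethyl, though one of carbon only and larger still. A weakening of at least modest size is therefore expected, a 3.0-fold higher number from compound 1 to compound 3 (0.48 log units; beyond the scatter), with a real chance that this assay again returns only a limit. For compound 3 the estimate is 4500 nM, in a range from 1500 nM to 12000 nM.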

Compound 3, concentration for 50% growth inhibition: 700 nM
The estimate for compound 3 lay 6.4-fold (0.81 log units) above the measured number; measured number below the stated range.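

In this assay, a ring in place of ethyl on this aromatic carbon does not by itself weaken growth inhibition, as the change to cycloheptyl gives a 2.1-fold lower number from compound 1 to compound 3 (0.33 log units; beyond the scatter). Piperidin-3-yl and cycloheptyl therefore move the number in opposite directions from ethyl, so the weakening seen with compound 2 does not extend to every ring at this position. The change between the two rings gives an at least 14-fold lower number from compound 2 to compound 3 (1.15 log units; beyond the scatter), but this step is only a bound, since compound 2 gives a limit and not a number: the limit of > 10000 nM in this assay, at which 1 of the 3 values shown sits.

Cycloheptyl and piperidin-3-yl differ both in ring size and in the ring nitrogen, and the compounds shown do not separate these two changes. Cyclohexyl would address the first, while a longer chain such as butyl would show whether a ring is needed at all.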